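The compounds below may be only part of what the source reports. "The series", "measured", "known", "first", "only" and "open" are said of these compounds alone.

In a functional assay on HepG2 cells (Homo sapiens) for inhibition, read by MTT assay, with a stated time of 72 h (on this read-out higher numbers stand for weaker inhibition and lower numbers for stronger inhibition), three compounds have been measured so far:

Compound 1 `O=C(Nc1ccc(Oc2ccnc3[nH]ccc23)cc1)c1cn(-c2ccccc2)c2ccccc2c1=O` gives 2250 nM.
Compound 2 `O=C(Nc1ccc(Oc2ccnc3[nH]ccc23)cc1)c1cn(-c2ccc(Cl)cc2)c2ccccc2c1=O` gives 250 nM.
Compound 3 `O=C(Nc1ccc(Oc2ccnc3[nH]ccc23)c(F)c1)c1cn(-c2ccccc2)c2ccccc2c1=O` gives 760 nM.

Compound 3 holds the second highest of these three numbers. Its nearest neighbour is compound 1, which differs from it only by a fluoro group; that step reads a 3.0-fold lower number from compound 1 to compound 3 (0.47 log units; beyond the scatter). Going by the values given here, compound 2 lies further off, at a number about as far below compound 3 as compound 1 lies above it, though no single-point step links compound 2 and compound 3.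

Compound 4 `O=C(Nc1ccc(Oc2ccnc3[nH]ccc23)c(F)c1)c1cn(-c2ccc(Cl)cc2)c2ccccc2c1=O` is not yet measured. It differs from compound 3 in one place: chloro in place of hydrogen on an aromatic carbon, the site being on an aromatic carbon of a six-membered aromatic ring of carbon only, para to a large group; cut one bond further out, the change reads phenyl to 4-chlorophenyl.

Among the compounds with values here, one measured step bears on this directly: the same chloro-for-hydrogen swap on compound 1 gave a 9.0-fold lower number from compound 1 to compound 2 (0.95 log units; beyond the scatter). A lowering of about that size is therefore expected here as well, a step of a 7.6-fold lower number from compound 3 to compound 4 (0.88 log units; beyond the scatter). Compound 4 is estimated at 100 nM in this assay, with a likely range from 40 nM to 260 nM.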

Compound 4, half-maximal inhibitory concentration: 380 nM
Compound 4: middle estimate off by 3.8-fold (0.58 log units), on the low side; measured number above the stated range.
By their numbers in this assay, from the lowest: compounds 2, 4 and 3 (each within the scatter of the next, the first and the last beyond it); then compound 1.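

The chloro swap is not a fixed gain that can be carried from one compound to another. With the fluoro group already present, it gives a 2.0-fold lower number from compound 3 to compound 4 (0.30 log units; within the scatter), and its size therefore depends on the core that carries it: the same change on two cores in this assay, a 9.0-fold lower number (0.95 log units; beyond the scatter) from compound 1 to compound 2 and a 2.0-fold lower number (0.30 log units; within the scatter) from compound 3 to compound 4, 4.5-fold (0.65 log units) apart, beyond the scatter of two such steps

The fluoro change shows the same dependence, since with the 4-chlorophenyl group already present it gives a 1.5-fold higher number from compound 2 to compound 4 (0.18 log units; within the scatter), so it too cannot be read as a fixed step: the same change on two cores in this assay, a 3.0-fold lower number (0.47 log units; beyond the scatter) from compound 1 to compound 3 and a 1.5-fold higher number (0.18 log units; within the scatter) from compound 2 to compound 4, 4.5-fold (0.65 log units) apart, beyond the scatter of two such steps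

Across these four compounds, the two changes do not simply add up: each gives a step beyond the scatter when made on compound 1, but a step within the scatter when made on a compound that already carries the other.

These compounds cannot tell what makes the two changes overlap, nor whether the same holds beyond this single pair of changes. As far as these compounds go, it remains open whether a methyl, a methoxy or an amine at the site that carries the chloro group would behave the same way, with and without the fluoro group.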